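Aryl variation on the imine carbon of the fused core

The compounds below may be only part of what the source reports. "The series", "measured", "known", "first", "only" and "open" are said of these compounds alone.

In a functional assay on MCF7 cells (Homo sapiens) for inhibition, read by sulforhodamine B assay, with a stated time of 72 h (on this read-out lower numbers stand for stronger inhibition and higher numbers for weaker inhibition), compound 1 `CC(c1ccc(-c2ccccc2)c(F)c1)c1nnc2n1N=C(c1ccc(OC(F)(F)F)cc1)CS2` gives 4800 nM. Compound 2 `CC(C)Cc1ccc(C(C)c2nnc3n2N=C(c2ccc(Cl)cc2)CS3)cc1` gives 8800 nM in this assay. Compound 3 `CC(c1ccc(-c2ccccc2)c(F)c1)c1nnc2n1N=C(c1ccc(Cl)cc1Cl)CS2` gives 7600 nM in this assay, the second highest of the three numbers; its nearest neighbour is compound 2 and its furthest is compound 1, and both gaps lie within the scatter, so no order among the three can be read.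

Compound 4 `CC(c1ccc(-c2ccccc2)c(F)c1)c1nnc2n1N=C(c1ccccc1)CS2` differs from compound 3 by phenyl in place of 2,4-dichlorophenyl on a carbon with a double bond to nitrogen. Among the compounds with values here, the one measured step that bears on this position is a 1.6-fold higher number from compound 1 to compound 3 (0.20 log units; within the scatter), which swaps one substituted aryl ring for another on the same carbon and stays within the scatter. Nothing measured shows what an unsubstituted phenyl does at this carbon, so the expectation can only be that the change produces no step beyond the scatter, in this assay as a 1.1-fold higher number from compound 3 to compound 4 (0.05 log units; within the scatter). Compound 4 is therefore estimated at 8500 nM in this assay, with a range from 3000 nM to 25000 nM.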

Compound 4, half-maximal inhibitory concentration: 7400 nM
The estimate for compound 4 lay 1.1-fold (0.06 log units) above the measured number; low and high end bracket the measured number.
By their numbers in this assay, from the lowest: compounds 1, 4, 3 and 2 (each within the scatter of the next).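

With the rest of the molecule held constant, removing the chlorine atoms gives a 1.0-fold lower number from compound 3 to compound 4 (0.01 log units; within the scatter), and removing the trifluoromethoxy group gives a 1.5-fold higher number from compound 1 to compound 4 (0.19 log units; within the scatter), both in this assay. Within the data shown here, the earlier step compared only two substituted aryl rings, whereas these steps add the unsubstituted phenyl as a reference and show that neither 2,4-dichlorophenyl nor 4-(trifluoromethoxy)phenyl can be told apart from it at this carbon. No measurement shown here offers an explanation for this flat result.

Still open, from the compounds shown here alone, is whether a phenyl ring carrying a dimethylamino group or a carboxylic acid would produce a step beyond the scatter. Going by these compounds, it is equally open whether a cyclohexyl ring or a pyridine ring in place of the phenyl would do so.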